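Compound 1 to compound 3: a side-chain exchange

A few compounds are considered here, and "the series" means these few. Any claim that something is new, unique, unknown or untested is made for them only; others in the source may bear on it.

In a functional assay on HL-60 cells (Homo sapiens) for cytotoxicity (on this read-out higher numbers stand for weaker inhibition and lower numbers for stronger inhibition), compound 1 `C=C(C(=O)O[C@@H]1/C(C)=C/[C@@]23O[C@@]2(C[C@H](C)[C@@H]3OC(C)=O)C(=O)[C@H](C)[C@H](OC(C)=O)[C@@H]2[C@H]([C@H]1OC)C2(C)C)C(C)O` gives < 10000 nM, which is a limit and not a number. Compound 2 `CCC(C)C(=O)O[C@@H]1[C@H]2[C@@H]([C@@H](OC(C)=O)[C@@H](C)C(=O)[C@@]34C[C@H](C)[C@H](O)[C@]3(/C=C(\C)[C@H]1OC(C)=O)O4)C2(C)C` gives < 10000 nM in this assay, likewise a limit. Compound 1 therefore stands at the limit of < 10000 nM in this assay, at which 2 of the 2 values shown sit, so the numbers give no exact position for it. Compound 3 `C/C=C(/C)C(=O)O[C@@H]1/C(C)=C/[C@@]23O[C@@]2(C[C@H](C)[C@@H]3OC(C)=O)C(=O)[C@H](C)[C@H](OC(C)=O)[C@@H]2[C@H]([C@H]1OC)C2(C)C` keeps the core of compound 1 and changes one place, on a carbonyl carbon: a group of 4 heavy atoms (4 carbon; no ring) in place of a group of 5 heavy atoms (4 carbon, 1 oxygen; no ring), on a carbonyl carbon. A 1-methylprop-1-en-1-yl group takes the place of a group of 5 heavy atoms with no common name. Among the compounds with values here, no measured step covers this exchange, so in this assay no expected step goes beyond the scatter, and neither direction is favoured. The expected change is a step that the limit leaves unreadable from compound 1 to compound 3. The estimated value for compound 3 is 6000 nM, with an expected range from 2000 nM to 15000 nM.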

Compound 3, half-maximal inhibitory concentration: < 10000 nM
Compound 3 was reported as a limit (the forecaster's own chance of this, stated with the estimate: 65%); the middle value does not contradict the limit.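

Within the data shown here, compound 1 and compound 3 are both reported as limits and not as numbers, so no step between them can be read. Whether 1-methylprop-1-en-1-yl in place of the original group shifts the read-out at all stays open, with every value at one limit: the limit of < 10000 nM in this assay, at which 3 of the 3 values shown sit.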